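The compounds below may be only part of what the source reports. "The series", "measured", "known", "first", "only" and "open" are said of these compounds alone.

In an in vitro functional assay on 1321-N1 cells for agonist activity at P2Y purinoceptor 2 (Homo sapiens), read by scintillation proximity assay and inositol phosphate accumulation (on this read-out higher numbers stand for an effect only at larger amounts of compound and lower numbers for an effect already at smaller amounts), compound 2 `O=c1ccn([C@@H]2O[C@H](COP(=O)(O)O)[C@@H](O)[C@H]2O)c(SCCc2ccccc2)n1` gives 1300 nM, the lowest of the two numbers obtained so far. Compound 3 `CSc1nc(=O)ccn1[C@@H]1O[C@H](COP(=O)(O)O)[C@@H](O)[C@H]1O` gives 2900 nM, and the step from compound 2 to compound 3 is a 2.2-fold higher number from compound 2 to compound 3 (0.35 log units; beyond the scatter). Compound 1 `CNc1nc(=O)ccn1[C@@H]1O[C@H](COP(=O)(O)O)[C@@H](O)[C@H]1O` reaches only the limit > 100000 nM in this assay, so no number is known for it; this is the limit of > 100000 nM in this assay, at which 1 of the 3 values shown sits. Exchanging the methylamino group on the aromatic carbon produced an at least 76-fold lower number from compound 1 to compound 2 (1.88 log units; beyond the scatter) and an at least 34-fold lower number from compound 1 to compound 3 (1.53 log units; beyond the scatter), both large.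

Compound 4 `O=c1ccn([C@@H]2O[C@H](COP(=O)(O)OP(=O)(O)O)[C@@H](O)[C@H]2O)c(SCCc2ccccc2)n1` differs from compound 2 elsewhere: a group of 4 heavy atoms (3 oxygen, 1 phosphorus; no ring) in place of a hydrogen atom, on an oxygen. This extends the phosphate end of the molecule, while the phenethylsulfanyl group of compound 2 is kept. None of the three measured steps touches this part of the structure; all of them concern the group on the aromatic carbon. No measured comparison therefore bears directly on the step from compound 2 to compound 4, and any expectation rests on thin ground. The expected step is a 4.3-fold lower number from compound 2 to compound 4 (0.64 log units; beyond the scatter), towards a lower number, with wide uncertainty. For compound 4 the value in this assay is estimated at 300 nM, within a range of 40 nM to 3000 nM.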

Compound 4, half-maximal effective concentration: 544 nM
Estimate against measurement, compound 4: 1.8-fold (0.26 log units) below; low and high end bracket the measured number.
By their numbers in this assay, from the lowest: compound 4; then compound 2; then compound 3. At a limit, above all of these: compound 1.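

Until now, every measured step in this assay concerned the group on the aromatic carbon, while the phosphate end of the molecule stayed the same. Within the data shown here, compound 4 shows for the first time that this end also matters: with the phenethylsulfanyl group kept, adding a group of 4 heavy atoms (3 oxygen, 1 phosphorus; no ring) on an oxygen whose other neighbour is phosphorus gives a 2.4-fold lower number from compound 2 to compound 4 (0.38 log units; beyond the scatter), a modest step that is beyond the scatter. This is the same size class as a 2.2-fold higher number from compound 2 to compound 3 (0.35 log units; beyond the scatter), whereas both replacements of the methylamino group gave large steps, and nothing measured here explains why the added group lowers the number.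

As far as these compounds go, this change is seen on one pair only, and it remains open whether it would act in the same direction or to the same extent on compound 3, with its methylsulfanyl group. Also open, from the compounds shown here alone, is how a third phosphate at the same end, or a longer chain such as phenylpropylsulfanyl in place of phenethylsulfanyl, would read on this scale.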